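The compounds below may be only part of what the source reports. "The series", "measured", "known", "first", "only" and "open" are said of these compounds alone.

Compound 1 `Cc1nn(C)c2c(O)nc(-c3ccccc3)nc12` gives 1020 nM in an assay on membranes from brain for binding affinity to adenosine receptor A1 (Rattus norvegicus), read by radioligand binding (a lower number here means a stronger inhibitor, a higher number a weaker inhibitor), the lower of the two numbers; compound 2 `COc1cccc(-c2nc(O)c3c(n2)c(C)nn3C)c1` gives 1470 nM in this assay, a step of a 1.4-fold higher number from compound 1 to compound 2 (0.16 log units; within the scatter). Compound 3 `Cc1nn(C)c2c(O)nc(-c3ccc(S(=O)(=O)NCCN(C)C)cc3)nc12` differs from compound 1 by (2-(dimethylamino)ethyl)sulfamoyl in place of hydrogen on an aromatic carbon. Among the compounds with values here, the only measured step that touches this position is the one from compound 1 to compound 2, which stayed within the scatter, and it concerns a far smaller group than the one entering here, so the data do not show how this assay answers such an addition. Compound 3 is therefore expected to give 1200 nM, between 300 nM and 5000 nM, a step of a 1.2-fold higher number from compound 1 to compound 3 (0.07 log units; within the scatter) that is expected to lie within the scatter.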

Compound 3, half-maximal inhibitory concentration: 68 nM
Compound 3: the middle estimate sits 18-fold (1.25 log units) above what was measured, and the stated range ends above it.
By their numbers in this assay, from the lowest: compound 3; then compounds 1 and 2 (each within the scatter of the next).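

In this assay the aromatic ring of compound 1 proves responsive to substitution: (2-(dimethylamino)ethyl)sulfamoyl, on an aromatic carbon para to a large group, gives a 15-fold lower number from compound 1 to compound 3 (1.18 log units; beyond the scatter) and so goes beyond the scatter, unlike the smaller methoxy change with its a 1.4-fold higher number from compound 1 to compound 2 (0.16 log units; within the scatter). The large group is thus tolerated here and goes with a lower number. Nothing available accounts for this step. The compounds shown do not separate the sulfamoyl part from the chain and its dimethylamino end. On these data alone, an unsubstituted sulfamoyl, a shorter chain or a carboxylic acid in place of the amine remains open.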